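This account rests on a few compounds, and the source may have more. Where it says the series, first, only, none or still open, it means among the compounds named here.

Measured compounds:
- compound 1 `CNC(=O)c1cc(C(=O)NC2CC2)cn(Cc2cccc(OC)c2)c1=O`: 3
- compound 2 `CNC(=O)c1cc(C(=O)NCCC2CCOCC2)cn(Cc2ccccc2)c1=O`: 3.6
- compound 3 `CNC(=O)c1cc(C(=O)NC2CCC2)cn(Cc2ccccc2)c1=O`: 3.8

In a physicochemical assay for lipophilicity, at pH 7.4 (a higher number here means a more lipophilic compound, a lower number a more polar compound), compound 1 gives the lowest of the three numbers: compound 2 stands higher by an amount beyond the scatter, and compound 3 higher still. Compound 4 `CNC(=O)c1cc(C(=O)NC2CC2)cn(CC2CCOCC2)c1=O` differs from compound 1 in one place: oxan-4-yl in place of 3-methoxyphenyl on a saturated chain carbon bound to an aromatic nitrogen. Among the compounds with values here, the only step measured so far, a number 0.20 log units higher from compound 2 to compound 3 (within the scatter), swaps groups on an amide-type nitrogen, a different place, and it stayed within the scatter, so no measured step bears directly on the change from compound 1 to compound 4. The expectation can therefore rest only on the description of the change itself, and a downward step a number 0.80 log units lower from compound 1 to compound 4 (beyond the scatter) is estimated, with wide uncertainty. For compound 4 the estimated value is 2.2, expected between 1.5 and 2.9.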

Compound 4, distribution coefficient: 1.5
The estimate for compound 4 lay 0.70 log units above the measured number; measured number inside the range.
By their numbers in this assay, from the lowest: compound 4; then compound 1; then compounds 2 and 3 (each within the scatter of the next).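

In this assay the exchange of 3-methoxyphenyl for oxan-4-yl on a saturated chain carbon bound to an aromatic nitrogen gives a number 1.50 log units lower from compound 1 to compound 4 (beyond the scatter) and the counts of hydrogen-bond donors and acceptors stay the same. The only earlier step (a number 0.20 log units higher from compound 2 to compound 3 (within the scatter)) was on an amide-type nitrogen, so this is the first step shown at this place and the first single change to go beyond the scatter. Nothing available explains the size of this step. On these data alone, whether a cyclohexyl group or an amine such as piperidin-4-yl at this place would give a number close to that of compound 4 remains open.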